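The source may hold more compounds than are shown below. What is called first, only, known or untested is meant among the compounds shown, and "the series" means these compounds.

Measured in a functional assay on G-361 cells (Homo sapiens) for inhibition, with a stated time of 72 h; on this read-out higher numbers stand for weaker inhibition and lower numbers for stronger inhibition:
- compound 1 `NC1CCC(Nc2nc(NCc3ccc(-c4ccco4)cc3)c3ncn(C4CCCC4)c3n2)CC1`: 164 nM
- compound 2 `CC(C)(O)CNc1nc(NCc2ccc(-c3ccco3)cc2)c2ncn(C3CCCC3)c2n1`: 17400 nM
- compound 3 `CC(C)(O)CNc1nc(NCc2ccc(-c3ccco3)nc2)c2ncn(C3CCCC3)c2n1`: 2100 nM

Compound 1 has the lowest number of the three, clearly apart from the other two. Compound 4 `NC1CCC(Nc2nc(NCc3cc(Cl)ccc3O)c3ncn(C4CCCC4)c3n2)CC1` keeps its 4-aminocyclohexyl and changes the other arm: 5-chloro-2-hydroxyphenyl in place of 4-(furan-2-yl)phenyl on a saturated chain carbon bound to a nitrogen on an aromatic ring. The large step of a 110-fold higher number from compound 1 to compound 2 (2.03 log units; beyond the scatter) lies at the kept group, so it says little here. The modest step of an 8.3-fold lower number from compound 2 to compound 3 (0.92 log units; beyond the scatter) lies at the changed place, but with a different entering group. Going by the values given here, no measured compound shows the loss of the furan-2-yl ring, so only a modest move toward weaker inhibition is expected. The expected step is a 4.3-fold higher number from compound 1 to compound 4 (0.63 log units; beyond the scatter). Compound 4 is estimated at 700 nM, within an expected range of 150 nM to 3500 nM.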

Compound 4, half-maximal inhibitory concentration: 390 nM
Compound 4: middle estimate off by 1.8-fold (0.25 log units), on the high side; measured number inside the range.
By their numbers in this assay, from the lowest: compound 1; then compound 4; then compound 3; then compound 2.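

With the 4-aminocyclohexyl kept, replacing the 4-(furan-2-yl)phenyl with the smaller 5-chloro-2-hydroxyphenyl costs only a modest amount in this assay (a 2.4-fold higher number from compound 1 to compound 4 (0.38 log units; beyond the scatter)). This position therefore accepts a group with no furan-2-yl ring and still gives fairly strong inhibition, and this step is much smaller than the one at the other arm (a 110-fold higher number from compound 1 to compound 2 (2.03 log units; beyond the scatter)). Nothing available explains this modest change. Still open, as far as these compounds go, is what the chlorine and the hydroxyl each contribute, and whether an amine in place of that hydroxyl would hold the number.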